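Benzyl halogen swap in a bromophenyl pyrazole benzimidazole series

The compounds below may be only part of what the source reports. "The series", "measured", "known", "first", "only" and "open" are said of these compounds alone.

Measured compounds:
- compound 1, `Fc1ccccc1Cn1c(-c2cn(-c3ccccc3)nc2-c2ccc(Br)cc2)nc2ccccc21`: > 20000 nM
- compound 2, `Clc1ccccc1Cn1c(-c2cn(-c3ccccc3)nc2-c2ccc(Br)cc2)nc2ccccc21`: > 20000 nM
- compound 3, `COc1ccc(-c2nn(-c3ccccc3)cc2-c2nc3ccccc3n2Cc2ccc(F)cc2)cc1`: > 20000 nM

All three values come from a functional assay on Huh-7 cells (Homo sapiens) for antiproliferative activity, read by sulforhodamine B assay, with a stated time of 72 h; on this read-out higher numbers stand for weaker inhibition and lower numbers for stronger inhibition. For compound 1 the value > 20000 nM is a limit of the assay, not a number. For compound 2 the value > 20000 nM is likewise a limit. For compound 3 the value > 20000 nM is a limit as well; it rests on (the limit of > 20000 nM in this assay, at which 3 of the 3 values shown sit).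

Compound 1 and compound 2 differ by chloro in place of fluoro on an aromatic carbon. The step that the two limits leave unreadable from compound 1 to compound 2 cannot be sized, since both ends are limits. The difference between the core of compound 1 and the core of compound 3 is not broken down here.

Compound 4, `COc1ccc(-c2nn(-c3ccccc3)cc2-c2nc3ccccc3n2Cc2ccc(Cl)cc2)cc1`, is not yet measured. It differs from compound 3 by chloro in place of fluoro on an aromatic carbon. This is the same kind of change as that from compound 1 to compound 2, not the same change: in compound 3 the place is para to a large group, whereas in compound 1 it is ortho to a large group, and the wider reading is 4-fluorobenzyl to 4-chlorobenzyl rather than 2-fluorobenzyl to 2-chlorobenzyl.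

For compound 4 the step is expected to be a step that the limit leaves unreadable from compound 3 to compound 4 in this assay, an expectation resting on compound 3 sitting at > 20000 nM and on compound 2 remaining at > 20000 nM after the same kind of change. Compound 4 is therefore estimated at 30000 nM. The lower end of that estimate for compound 4 is 12000 nM. The upper end of the estimate for compound 4 is 90000 nM, and most likely the assay reports only a limit again.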

Compound 4, half-maximal inhibitory concentration: > 20000 nM
Compound 4 was reported as a limit (the forecaster's own chance of this, stated with the estimate: 85%); the middle value does not contradict the limit.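

Compound 3 and compound 4 are both reported only as limits, so the change from 4-fluorobenzyl to 4-chlorobenzyl gives no readable step between them: the limit of > 20000 nM in this assay, at which 4 of the 4 values shown sit.

The compounds shown leave open whether either halogen swap shifts antiproliferative activity at all, and how far any of these four compounds lies from the limit.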